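Para substituent removal in a quinazolinedione anilino series

A few compounds are considered here, and "the series" means these few. Any claim that something is new, unique, unknown or untested is made for them only; others in the source may bear on it.

Measured so far:
- compound 1, `CCOc1ccc(NC2=CC(=O)c3ncncc3C2=O)cc1`: 0.02 ug/mL
- compound 2, `O=C1C(Nc2ccc(F)cc2)=CC(=O)c2ncncc21`: 0.07 ug/mL

In a functional assay on SK-OV-3 cells (Homo sapiens) for cytotoxicity, read by MTT assay, with a stated time of 72 h (on this read-out higher numbers stand for weaker inhibition and lower numbers for stronger inhibition), compound 1 gives 0.02 ug/mL. For the measured compounds named here, compound 2 gives 0.07 ug/mL in this assay and stands as the higher of the two numbers; the one measured step, a 3.5-fold higher number from compound 1 to compound 2 (0.54 log units; beyond the scatter), separates it from compound 1 and is beyond the scatter.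

Compound 3, `O=C1C(Nc2ccccc2)=CC(=O)c2ncncc21`, is not yet measured. It differs from compound 2 by hydrogen in place of fluoro on an aromatic carbon. Going by the values given here, no measured step removes a substituent from this position entirely, so the only bearing comes from the ethoxy-to-fluoro exchange, which was modest in size. The expectation for compound 3 in this assay is therefore a step of about a 1.1-fold higher number from compound 2 to compound 3 (0.06 log units; within the scatter), that is, a number near that of compound 2 and most likely within the scatter. Compound 3 is estimated at 0.08 ug/mL, with a range from 0.03 ug/mL to 0.2 ug/mL.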

Compound 3, half-maximal inhibitory concentration: < 0.01 ug/mL
Compound 3 ended at the assay's limit; the forecaster's own chance of this, stated with the estimate: 3%; middle value at least 8.0-fold (0.90 log units) away from the limit.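

In this assay compound 3 carries a limit of the assay and not a number: the limit of < 0.01 ug/mL in this assay, at which 1 of the 3 values shown sits. The earlier compounds shown here only exchanged one substituent for another, whereas hydrogen in place of fluoro, on the aromatic carbon para to a large group, gives an at least 7.0-fold lower number from compound 2 to compound 3 (0.84 log units; beyond the scatter), so a substituent at this place is not needed for a low number. Hydrogen in place of ethoxy gives an at least 2.0-fold lower number from compound 1 to compound 3 (0.30 log units; that floor lies within the scatter), so compound 3 is not firmly set apart from compound 1.

How far the true figure of compound 3 lies past the limit remains open, and the data give no reason for the step from fluoro to hydrogen. Also open, on these data alone, is how an amine, a carboxylic acid or a longer alkoxy chain on this carbon would read.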